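Ester amino acid variants on the shared core

This account rests on a few compounds, and the source may have more. Where it says the series, first, only, none or still open, it means among the compounds named here.

Measured so far:
compound 1 `CCCCCCCCCCC[C@@H](C[C@@H]1OC(=O)[C@H]1CCCCCC)OC(=O)[C@H](C)NC=O` — 43 nM
compound 2 `CCCCCCCCCCC[C@@H](C[C@@H]1OC(=O)[C@H]1CCCCCC)OC(=O)[C@@H](NC(C)=O)C(C)C` — 460 nM
compound 3 `CCCCCCCCCCC[C@@H](C[C@@H]1OC(=O)[C@H]1CCCCCC)OC(=O)[C@@H](NC(C)=O)C(C)CC` — 430 nM

Compound 3 holds the second highest number of the three in an assay on COS-7 cells for inhibition of diacylglycerol lipase-alpha (Homo sapiens), read by scintillation counting; a lower number here means a stronger inhibitor, a higher number a weaker inhibitor. Its nearest neighbour is compound 2, with a 1.1-fold lower number from compound 2 to compound 3 (0.03 log units; within the scatter), a gap within the scatter. Its furthest is compound 1, with a 10-fold higher number from compound 1 to compound 3 (1.00 log units; beyond the scatter). The next compound, compound 4 `CCCCCCCCCCC[C@@H](C[C@@H]1OC(=O)[C@H]1CCCCCC)OC(=O)[C@@H]1CCCN1C=O`, carries 1-formylpyrrolidin-2-yl in place of 1-acetamido-2-methylbutyl on a carbonyl carbon. Among the measured compounds shown here, two measured steps bear on it: an 11-fold higher number from compound 1 to compound 2 (1.03 log units; beyond the scatter) and a 10-fold higher number from compound 1 to compound 3 (1.00 log units; beyond the scatter), both large rises when the formyl-bearing group of compound 1 gives way to acetamido groups with larger side chains. For the measured compounds named here, compound 4 returns the formyl group but closes the chain into a ring; no measured pair shows the effect of the ring alone. The step is therefore expected to fall partway back toward compound 1, so a 3.6-fold lower number from compound 3 to compound 4 (0.55 log units; beyond the scatter) is expected, a moderate drop rather than a full return. Compound 4 is thus estimated at 120 nM, within a range of 35 nM to 450 nM.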

Compound 4, half-maximal inhibitory concentration: 1100 nM
Compound 4: middle estimate off by 9.2-fold (0.96 log units), on the low side; measured number above the stated range.
By their numbers in this assay, from the lowest: compound 1; then compounds 3 and 2 (each within the scatter of the next); then compound 4.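

In this assay, a formyl group on the ring of compound 4 does not bring back the low number of compound 1 (a 26-fold higher number from compound 1 to compound 4 (1.41 log units; beyond the scatter)), so a formyl group alone does not set the number at this carbonyl carbon. 1-Formylpyrrolidin-2-yl also stands above both acetamido groups (a 2.6-fold higher number from compound 3 to compound 4 (0.41 log units; beyond the scatter); a 2.4-fold higher number from compound 2 to compound 4 (0.38 log units; beyond the scatter)), even though it has fewer heavy atoms than either, so compound 4 goes against any ordering of this series by group size. No evidence on hand accounts for these steps.

Ring closure and the change of acyl group occur together in every step to compound 4, so their separate shares cannot be read. Also open, on these data alone, is how 1-acetylpyrrolidin-2-yl or 1-formamido-2-methylpropyl would stand on this carbonyl carbon.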